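Longer acid chain on the shared core of compound 3

The source may hold more compounds than are shown below. What is called first, only, known or untested is meant among the compounds shown, and "the series" means these compounds.

Compound 3 `C=CCCCCOc1ccc2c(=O)c(-c3ccc(O)cc3)coc2c1` gives 150 nM in an assay (Cricetulus griseus) for inhibition of aldehyde dehydrogenase, mitochondrial (Homo sapiens) (on this read-out higher numbers stand for weaker inhibition and lower numbers for stronger inhibition), the highest of the three numbers measured. Compound 1 `NCCCCCCOc1ccc2c(=O)c(-c3ccc(O)cc3)coc2c1` gives 100 nM and compound 2 `O=C(O)CCCCCCCOc1ccc2c(=O)c(-c3ccc(O)cc3)coc2c1` gives 40 nM, so the steps are a 1.5-fold higher number from compound 1 to compound 3 (0.18 log units; within the scatter) and a 3.8-fold higher number from compound 2 to compound 3 (0.57 log units; beyond the scatter); only the latter lies beyond the scatter. Compound 4 `O=C(O)CCCCCCCCCCCOc1ccc2c(=O)c(-c3ccc(O)cc3)coc2c1` is not yet measured. It differs from compound 3 in one place: 7-carboxyheptyl in place of vinyl on a saturated chain carbon, four bonds along the chain from an oxygen on an aromatic ring. The step that bears most directly on this change is a 3.8-fold higher number from compound 2 to compound 3 (0.57 log units; beyond the scatter), which read in the opposite direction shows that a carboxyalkyl chain at this position lowered the number modestly; a 2.5-fold lower number from compound 1 to compound 2 (0.40 log units; beyond the scatter) points the same way. Going by the values given here, nothing among the measured compounds tells how a chain as long as 7-carboxyheptyl behaves, so the step from compound 3 is expected to be a 3.3-fold lower number from compound 3 to compound 4 (0.52 log units; beyond the scatter), a modest lowering with a broad range. Compound 4 is therefore estimated at 45 nM, between 12 nM and 150 nM.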

Compound 4, half-maximal inhibitory concentration: 130 nM
Beside the measured number, compound 4's estimate is 2.9-fold (0.46 log units) below it; measured number inside the range.
By their numbers in this assay, from the lowest: compound 2; then compounds 1, 4 and 3 (each within the scatter of the next).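

In this assay, going by these compounds alone, a carboxylic acid at the chain end no longer sets a compound apart once the chain is as long as 7-carboxyheptyl: compound 4 sits level with the vinyl-ended compound 3 (a 1.2-fold lower number from compound 3 to compound 4 (0.06 log units; within the scatter)) and with the amine-ended compound 1 (a 1.3-fold higher number from compound 1 to compound 4 (0.11 log units; within the scatter)). The shorter acid chain of compound 2 stands apart from it (a 3.3-fold higher number from compound 2 to compound 4 (0.51 log units; beyond the scatter)). Among these compounds, then, the lower number of compound 2 goes with that particular chain and not with a terminal carboxylic acid as such, so chain length counts at this position.

Where between these two acid chains the number begins to rise stays open, as does how an amine or an ester on a longer chain would behave. Nothing available explains why the longer acid chain differs from the shorter one.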